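The compounds below may be only part of what the source reports. "The series", "measured", "known", "first", "only" and "open" are said of these compounds alone.

Measured compounds:
- compound 1, `CN(C)c1ccc(C(=O)Nc2cccc(NC(=O)COc3ccc4c(c3)NC(=O)CC4)c2)cc1`, gives > 10000 nM, which is a limit of the assay
- compound 2, `Cc1coc2cc(OCC(=O)Nc3cccc(NC(=O)c4ccc(N(C)C)cc4)c3)ccc2c1=O`, gives > 10000 nM, again a limit
- compound 3, `CCCC(=O)Nc1cccc(NC(=O)COc2ccc3c(=O)ccoc3c2)c1`, gives 1430 nM

All three were tested in an assay on isolated protein for inhibition of Rho-associated protein kinase 1 (Homo sapiens), read by scintillation counting, radiometric assay and 33P incorporation, with a stated time of 40 min, in the presence of a further agent that is not named here; on this read-out higher numbers stand for weaker inhibition and lower numbers for stronger inhibition. Compound 1 reaches only a limit there, so no number is attached to it. Compound 2 likewise stops at a limit. Compound 3 is therefore the only one of the three with an actual number, standing apart from the limit of > 10000 nM in this assay, at which 2 of the 3 values shown sit. Within the data shown here, with no pair of measured compounds differing in a single place, no measured step is available to guide the next move.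

Compound 4, `Cn1ccc(S(=O)(=O)Nc2cccc(NC(=O)COc3ccc4c(=O)ccoc4c3)c2)n1`, has not yet been measured in this assay. It differs from compound 3 in one place: a group of 9 heavy atoms (4 carbon, 2 nitrogen, 2 oxygen, 1 sulfur; one five-membered aromatic ring with 2 hetero atoms) in place of a group of 5 heavy atoms (4 carbon, 1 oxygen; no ring), on a nitrogen on an aromatic ring. The group that enters is larger than the one it replaces and brings a five-membered aromatic ring with 2 hetero atoms and more hydrogen-bond acceptors. Because compound 3 gives 1430 nM, the starting point for compound 4 is a moderate value, and a change of this size could move it in either direction. On balance the step from compound 3 to compound 4 is expected to be a 2.1-fold higher number from compound 3 to compound 4 (0.32 log units; beyond the scatter), a modest shift toward weaker inhibition that may still fall within the scatter. Compound 4 is thus estimated at 3000 nM, with a range from 700 nM to 15000 nM.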

Compound 4, half-maximal inhibitory concentration: > 10000 nM
Compound 4: only a limit was reported; the forecaster's own chance of this, stated with the estimate: 35%; middle value at least 3.3-fold (0.52 log units) from the limit.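

In this assay, the result shows that the nitrogen on an aromatic ring is a place where a change can cost a clear amount of inhibition: putting the group with one five-membered aromatic ring with 2 hetero atoms in place of propylcarbonyl gives an at least 6.9-fold higher number from compound 3 to compound 4 (0.84 log units; beyond the scatter). Compound 4 gives > 10000 nM, which is a limit and not a number, so the step has a known minimum but no known full size. Compound 3 remains the only compound here with an actual number, and the others offer no finer ranking: the limit of > 10000 nM in this assay, at which 3 of the 4 values shown sit.

This single change swaps several features at once, including the size of the group, the sulfur-containing link and the ring, so the compounds shown cannot separate their contributions. Going by these compounds, it also remains open how this position would respond to a smaller change, such as a longer acyl chain like pentanoyl, or a simple methanesulfonyl group that carries the sulfur without the ring.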